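Swapping the aryl end of the dienone for a thiophene

A few compounds are considered here, and "the series" means these few. Any claim that something is new, unique, unknown or untested is made for them only; others in the source may bear on it.

Compound 1 `COc1ccccc1/C=C/C(=O)/C=C/c1ccc(OCc2cn(CCOc3cc(=O)oc4ccccc34)nn2)c(OC)c1` gives 11% in a functional assay on PC-3 cells (Homo sapiens) for inhibition, read by sulforhodamine B assay, with a stated time of 48 h, tested at 50 uM; a lower number here means less inhibition of growth, a higher number more inhibition of growth at the concentration tested.
Compound 2 `COc1cc(/C=C/C(=O)/C=C/c2cc(OC)c(OC)c(OC)c2)ccc1OCc1cn(CCOc2cc(=O)oc3ccccc23)nn1` gives 22% in this assay.
Compound 3 `COc1cccc(/C=C/C(=O)/C=C/c2ccc(OCc3cn(CCOc4cc(=O)oc5ccccc45)nn3)c(OC)c2)c1` gives 13% in this assay.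

Compound 3 sits second highest of the three numbers; its nearest neighbour is compound 1 and its furthest is compound 2, and both gaps lie within the scatter. Compound 4 `COc1cc(/C=C/C(=O)/C=C/c2cccs2)ccc1OCc1cn(CCOc2cc(=O)oc3ccccc23)nn1` differs from compound 3 only at one place: thiophen-2-yl in place of 3-methoxyphenyl on a double-bonded chain carbon bound to a double-bonded chain carbon. The steps that touch this position are a number 2 percentage points higher from compound 1 to compound 3 (within the scatter) and a number 9 percentage points lower from compound 2 to compound 3 (within the scatter), together with a number 11 percentage points higher from compound 1 to compound 2 (beyond the scatter), so exchanging the aryl group here has moved the readout little, with only the 3,4,5-trimethoxyphenyl compound reaching beyond the scatter. Going by the values given here, no measured step introduces a thiophen-2-yl. Compound 4 is therefore expected to stay near compound 3, with a number 1 percentage points higher from compound 3 to compound 4 (within the scatter) lying within the scatter. The estimate for compound 4 in this assay is 14%, within 4% to 26%.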

Compound 4, percent growth inhibition at one concentration: 12%
Beside the measured number, compound 4's estimate is 2 percentage points above it; measured number inside the range.
By their numbers in this assay, from the lowest: compounds 1, 4, 3 and 2 (each within the scatter of the next, the first and the last beyond it).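

In this assay, a five-membered sulfur-containing ring at this place reads no differently from the methoxyphenyl groups, with a number 1 percentage points lower from compound 3 to compound 4 (within the scatter) and a number 1 percentage points higher from compound 1 to compound 4 (within the scatter). Even against the 3,4,5-trimethoxyphenyl group the exchange stays inside the scatter, with a number 10 percentage points lower from compound 2 to compound 4 (within the scatter) as the step, so the thiophen-2-yl group does not separate from any of the three earlier compounds. Nothing measured here offers an explanation for this. Still open, going by these compounds, is whether an amine or a carboxylic acid carried on the ring at this place would move the number beyond the scatter.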